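The compounds below may be only part of what the source reports. "The series", "measured", "known", "first", "only" and "open" are said of these compounds alone.

Measured so far:
compound 1 `COc1c(C)cnc(Cn2cc(C#CCNc3cccc4c3C(=O)N(C3CCC(=O)NC3=O)C4=O)c3c(Cl)nc(N)nc32)c1C` gives 1980 nM
compound 2 `COc1c(C)cnc(Cn2cc(C#CCCNc3cccc4c3C(=O)N(C3CCC(=O)NC3=O)C4=O)c3c(Cl)nc(N)nc32)c1C` gives 630 nM

Both numbers come from a functional assay on MCF7 cells (Homo sapiens) for inhibition, read by MTT assay, with a stated time of 72 h; a lower number here means a stronger inhibitor, a higher number a weaker inhibitor. Compound 2 stands at the lower of the two numbers in this assay; compound 1 sits beyond the scatter of it. Compound 3 `COc1c(C)cnc(Cn2cc(C#CCCNc3cccc4c3C(=O)N(C3CCC(=O)N(C)C3=O)C4=O)c3c(Cl)nc(N)nc32)c1C` is not yet measured. It differs from compound 2 by methyl in place of hydrogen on an amide-type nitrogen in a ring. Within the data shown here, no step of this kind has been measured, so the expectation rests on the structural change alone. A large step towards a higher number in this assay is expected, a 32-fold higher number from compound 2 to compound 3 (1.50 log units; beyond the scatter), clearly beyond the scatter. Compound 3 is therefore estimated at 20000 nM, with a range from 4000 nM to 80000 nM.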

Compound 3, half-maximal inhibitory concentration: 2460 nM
Compound 3: middle estimate off by 8.1-fold (0.91 log units), on the high side, and the stated range ends above it.
By their numbers in this assay, from the lowest: compound 2; then compounds 1 and 3 (each within the scatter of the next).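

Methyl in place of hydrogen on the amide-type nitrogen, the change from 2,6-dioxopiperidin-3-yl to 1-methyl-2,6-dioxopiperidin-3-yl, gives a 3.9-fold higher number from compound 2 to compound 3 (0.59 log units; beyond the scatter) in this assay and counts as a modest step. This position therefore affects the read-out, but compound 3 still gives a measured number of 2460 nM and the amide hydrogen is not essential for a finite value here.

From the compounds shown here alone, whether ethyl or a longer chain on this nitrogen would shift the number further remains open, as does whether methyl acts alike on the chain of compound 1. Nothing available bears on the reason for the step.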